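A few compounds are considered here, and "the series" means these few. Any claim that something is new, unique, unknown or untested is made for them only; others in the source may bear on it.

Measured so far:
compound 1 `CC(C)(C)C1=NN(c2ccc(C(F)(F)F)cc2)C(c2ccc(O)cc2)C1`: 94.2%
compound 2 `CC(C)(C)C1=NN(c2ccc(C(=O)O)cc2)C(c2ccc(O)cc2)C1`: 47.9%
compound 3 `CC(C)(C)C1=NN(c2cccc(Cl)c2)C(c2ccc(O)cc2)C1`: 96.8%

In an assay on isolated protein for inhibition of protein kinase C zeta type (Homo sapiens), with a stated time of 4 min, tested at 62.5 uM (a higher number here means more inhibition at the concentration tested (going by the name of the read-out), a lower number less inhibition), compound 3 gives 96.8%, the highest of the three numbers. Compound 1 sits within the scatter of it, while compound 2 lies far below on the values alone. Compound 4 `Cc1cccc(N2N=C(C(C)(C)C)CC2c2ccc(O)cc2)c1` differs from compound 3 by methyl in place of chloro on an aromatic carbon. Going by the values given here, the one measured step, a number 46.3 percentage points lower from compound 1 to compound 2 (beyond the scatter), concerns carboxy entering for trifluoromethyl and so bears only loosely on this exchange; no step with methyl or with chloro leaving has been measured. Since both compound 1 and compound 3 carry a group of one heavy atom count or more with no net charge and sit high, the change to methyl is expected to leave inhibition near the present level: compound 4 is estimated at 90%, with a range of 75% to 98%, which means an expected step of a number 6.8 percentage points lower from compound 3 to compound 4 (within the scatter) within the scatter.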

Compound 4, a percentage reported as inhibition, at one concentration (the size of the read-out at that concentration, not a potency): 91.7%
The estimate for compound 4 lay 1.7 percentage points below the measured number; measured number inside the range.
By their numbers in this assay, from the lowest: compound 2; then compounds 4, 1 and 3 (each within the scatter of the next).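

Going by these compounds alone, exchanging 3-chlorophenyl for 3-methylphenyl gives a number 5.1 percentage points lower from compound 3 to compound 4 (within the scatter) in this assay and is the only step read at this place, on an aromatic carbon meta to a large group. Chloro is therefore not needed here for high inhibition, as methyl leaves compound 4 at 91.7% in this series. Nothing available bears on why the exchange makes so little difference.

On these data alone, whether an amine, a methoxy group or a longer chain such as butyl would hold inhibition at this place stays open. As far as these compounds go, the effect of any change to the shared core is also open.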